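Working notes: methyl on the amide nitrogen of compound 3

The source may hold more compounds than are shown below. What is called first, only, known or untested is meant among the compounds shown, and "the series" means these compounds.

Going by the values given here, compound 3 `NC(=O)[C@H]1CN(c2ccc(-n3cc(-c4ccccn4)cn3)c(F)c2)C(=O)O1` stands second highest of the three numbers so far in an ADME assay on L02 cells (Homo sapiens) for cytotoxicity, read by MTT assay, with a stated time of 48 h (a higher number here means a weaker inhibitor, a lower number a stronger inhibitor), where compound 3 gives 119 ug/mL. Compound 1 `O=C1O[C@@H](CO)CN1c1ccc(-n2cc(-c3ccccn3)cn2)c(F)c1` gives 59 ug/mL in this assay, and compound 2 `CN(C)S(=O)(=O)NC[C@H]1CN(c2ccc(-n3cc(-c4ccccn4)cn3)c(F)c2)C(=O)O1` gives 158 ug/mL. The steps joining the three are a 2.0-fold higher number from compound 1 to compound 3 (0.30 log units; within the scatter), a 1.3-fold lower number from compound 2 to compound 3 (0.12 log units; within the scatter) and a 2.7-fold higher number from compound 1 to compound 2 (0.43 log units; beyond the scatter); only the last one clears the scatter, and it does so by a modest margin.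

Compound 4 `CNC(=O)[C@H]1CN(c2ccc(-n3cc(-c4ccccn4)cn3)c(F)c2)C(=O)O1` differs from compound 3 by methyl in place of hydrogen on an amide-type nitrogen. Among the compounds with values here, no measured step touches an amide-type nitrogen, so nothing bears on this change directly. The steps that come closest are those that exchange the whole substituent on the saturated ring carbon, a 2.0-fold higher number from compound 1 to compound 3 (0.30 log units; within the scatter) and a 1.3-fold lower number from compound 2 to compound 3 (0.12 log units; within the scatter), and both stay within the scatter even though they swap groups far larger than a single methyl. Within the data shown here, the one step beyond the scatter, a 2.7-fold higher number from compound 1 to compound 2 (0.43 log units; beyond the scatter), also concerns that substituent and is modest. On this basis no step beyond the scatter is expected in this assay, in either direction.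

Compound 4 is therefore estimated at 120 ug/mL, with a range from 60 ug/mL to 240 ug/mL, which means an expected step of a 1.0-fold higher number from compound 3 to compound 4 (0.00 log units; within the scatter).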

Compound 4, half-maximal inhibitory concentration: 217 ug/mL
Beside the measured number, compound 4's estimate is 1.8-fold (0.26 log units) below it; low and high end bracket the measured number.
By their numbers in this assay, from the lowest: compounds 1, 3, 2 and 4 (each within the scatter of the next, the first and the last beyond it).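

In this assay, going by these compounds alone, methyl in place of hydrogen on an amide-type nitrogen gives a 1.8-fold higher number from compound 3 to compound 4 (0.26 log units; within the scatter), the first reading at this position, and the methyl adds no step beyond the scatter. Compound 4 also stays close to the sulfamide-bearing compound, with a 1.4-fold higher number from compound 2 to compound 4 (0.14 log units; within the scatter), so methylcarbamoyl and ((dimethylsulfamoyl)amino)methyl on the saturated ring carbon cannot be told apart here. Against hydroxymethyl the reading is different: carbamoyl gives a 2.0-fold higher number from compound 1 to compound 3 (0.30 log units; within the scatter), while methylcarbamoyl gives a 3.7-fold higher number from compound 1 to compound 4 (0.57 log units; beyond the scatter), which clears the scatter, though only modestly, and no measurement at hand gives a reason for any of these steps.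

The compounds shown leave open whether a larger group on the amide-type nitrogen, such as ethyl, a second methyl or a longer chain, would carry the number beyond the scatter from compound 3. They also leave open how a carboxylic acid or an amine in place of the carbamoyl on the saturated ring carbon would read in this assay, since only neutral amide, alcohol and sulfamide side groups appear so far.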